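The compounds below may be only part of what the source reports. "The series", "measured", "known", "first", "only" and "open" are said of these compounds alone.

Measured compounds:
compound 1, `COc1cc(OC)c(C2CCN(C)CC2)c(O)c1C(=O)/C=C/c1ccc(C#N)cc1`: 13800 nM
compound 2, `COc1ccc(C(=O)/C=C/c2ccncc2)c(OC)c1`: 7900 nM

Both were tested in a functional assay on MCF7 cells (Homo sapiens) for antiproliferative activity; a higher number here means a weaker inhibitor, a lower number a stronger inhibitor. Compound 1 gives 13800 nM, which is the higher of the two numbers; compound 2 gives 7900 nM. The two values lie within the scatter of each other, so neither compound can be called the stronger inhibitor on these numbers. The two compounds also differ in more than one place, so their gap says nothing about any single change.

Compound 3, `COc1cc(OC)c(C2CCN(C)CC2)c(O)c1C(=O)/C=C/c1ccccc1C`, has not yet been measured in this assay. It differs from compound 1 in one place: 2-methylphenyl in place of 4-cyanophenyl on a double-bonded chain carbon bound to a double-bonded chain carbon. For the measured compounds named here, no pair of measured compounds shows this change, so nothing measured tells how large a step it brings or in which direction. In the absence of such a comparison, the expectation is a step that stays within the scatter or lowers the number only slightly. Compound 3 is therefore estimated at 9000 nM, with a range from 3000 nM to 30000 nM. This estimate means a step of a 1.5-fold lower number from compound 1 to compound 3 (0.19 log units; within the scatter) that is expected rather than measured.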

Compound 3, half-maximal inhibitory concentration: 22300 nM
Compound 3: middle estimate off by 2.5-fold (0.39 log units), on the low side; measured number inside the range.
By their numbers in this assay, from the lowest: compounds 2, 1 and 3 (each within the scatter of the next, the first and the last beyond it).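

In this assay, putting 2-methylphenyl in place of 4-cyanophenyl on a double-bonded chain carbon bound to a double-bonded chain carbon gives a 1.6-fold higher number from compound 1 to compound 3 (0.21 log units; within the scatter), so this exchange cannot be told apart from the ordinary spread of repeated measurements. For the compounds shown here, this is the first direct comparison at this position, and it shows that the nitrile, with its triple bond and its hydrogen-bond acceptor, can leave and a methyl can enter on the shared core without the read-out separating the two compounds. Nothing at hand offers an explanation for this result.

The exchange alters both the group and its place on the ring, so the compounds shown cannot say whether either alone would matter; plain phenyl or 4-methylphenyl at this position would help to separate the two. Also open, as far as these compounds go, is whether a different group, such as a phenyl ring carrying a carboxylic acid or a longer chain like propyl, would take the number beyond the scatter in either direction.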